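A fluoro added to the phenyl ring

This account rests on a few compounds, and the source may have more. Where it says the series, first, only, none or still open, it means among the compounds named here.

Compound 1 `Fc1ccc(NC(=S)Nc2nc3ccc(F)cc3s2)cc1` gives 47700 nM in a functional assay on B16-F10 cells (Mus musculus) for cytotoxicity, read by MTT assay, with a stated time of 48 h; a higher number here means a weaker inhibitor, a lower number a stronger inhibitor. Compound 2 `Cc1ccc2nc(NC(=S)Nc3ccc(F)cc3)sc2c1` gives > 50000 nM in this assay. Compound 3 `CCOc1ccc2nc(NC(=S)Nc3ccccc3)sc2c1` gives > 50000 nM in this assay.

The value of compound 2 is a limit of the assay, not a number. The value of compound 3 is likewise a limit, so compound 3 stands at the edge of what the assay can report, with the limit of > 50000 nM in this assay, at which 2 of the 3 values shown sit.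

Compound 4 `CCOc1ccc2nc(NC(=S)Nc3ccc(F)cc3)sc2c1` differs from compound 3 only in one respect: fluoro in place of hydrogen on an aromatic carbon. Going by the values given here, no measured step covers this change. Among the compounds with values here, the single measured step, an at least 1.0-fold higher number from compound 1 to compound 2 (0.02 log units; that floor lies within the scatter), concerns another place and lies within the scatter; both compound 1 and compound 2 carry the fluoro on the phenyl ring and sit at or near the limit. No step beyond the scatter is therefore expected in this assay, and the step that the limit leaves unreadable from compound 3 to compound 4 is an estimate only. Compound 4 is expected to give 55000 nM, between 30000 nM and 120000 nM.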

Compound 4, half-maximal inhibitory concentration: > 50000 nM
Compound 4: no number, only a limit; the forecaster's own chance of this, stated with the estimate: 70%; the middle value does not contradict the limit.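

With the fluoro on the phenyl ring, compound 4 in this assay also stands at a limit of the assay and not at a number, so phenyl to 4-fluorophenyl brings no readable gain on the ethoxy compound, and the steps to compound 4 from compound 3 and from compound 2 cannot be read: the limit of > 50000 nM in this assay, at which 3 of the 4 values shown sit.

Going by these compounds alone, the one readable step, for ethoxy in place of fluoro, is an at least 1.0-fold higher number from compound 1 to compound 4 (0.02 log units; that floor lies within the scatter).

From the compounds shown here alone, what number compound 2, compound 3 and compound 4 would give stays open, as does whether an amine or a carboxylic acid in place of the fluoro on the phenyl ring would bring a value under the limit.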